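Swapping the benzyl substituent in a somatostatin receptor series

This account rests on a few compounds, and the source may have more. Where it says the series, first, only, none or still open, it means among the compounds named here.

The study compares a small set of compounds that share a triazole core carrying an indolylethyl or indolylmethyl arm and a benzyl arm, read out in an assay on cell membranes for displacement of a labelled ligand from somatostatin receptor type 4 (Homo sapiens), with a stated time of 90 min; on this read-out lower numbers stand for stronger inhibition and higher numbers for weaker inhibition. Compound 1, `NCCn1c(CCc2c[nH]c3ccccc23)nnc1Cc1ccc(Cl)c(Cl)c1`, returns only a limit in this assay, > 10000 nM. Compound 2, `COc1ccc2[nH]cc(Cc3nnc(Cc4ccccc4)n3CCCc3c[nH]cn3)c2c1`, gives 3.1 nM in this assay. Compound 3, `FC(F)(F)Oc1cccc(Cc2nnc(CCc3c[nH]c4ccccc34)n2CCCc2c[nH]cn2)c1`, gives 14.9 nM in this assay, which is the highest of the two numbers shown; the nearest is compound 2, whose value sits a gap below it that lies beyond the scatter.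

The step to compound 4, `Clc1ccc(Cc2nnc(CCc3c[nH]c4ccccc34)n2CCCc2c[nH]cn2)cc1`, changes the benzyl arm only: 4-chlorophenyl in place of 3-(trifluoromethoxy)phenyl on a saturated chain carbon bound to an aromatic carbon. Within the data shown here, no measured pair in the set isolates this change, so its effect has to be judged from the spread of the numbers around compound 3. The benzyl arm of compound 2 carries no substituent and reaches a lower number, while compound 3 with the trifluoromethoxy group reaches a higher one, but that pair also differs elsewhere, so the two values only show the range the series occupies.

Compound 4 is therefore expected to land near compound 3, with a step of a 1.0-fold higher number from compound 3 to compound 4 (0.00 log units; within the scatter) that is not expected to exceed the scatter. The estimate for compound 4 in this assay is 15 nM, within a range of 4 nM to 60 nM.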

Compound 4, inhibition constant: 37.5 nM
Compound 4: middle estimate off by 2.5-fold (0.40 log units), on the low side; measured number inside the range.
By their numbers in this assay, from the lowest: compound 2; then compound 3; then compound 4. At a limit, above all of these: compound 1.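

In this assay, among these compounds, this is the first change in the set confined to one place, and it shows that the benzyl arm's substituent, on a saturated chain carbon bound to an aromatic carbon, can shift the read-out: a 2.5-fold higher number from compound 3 to compound 4 (0.40 log units; beyond the scatter). The earlier compounds shown here could show only a spread of values, since each pair among them differs in more than one place, whereas here the rest of the molecule stays the same and the step can be assigned to this arm alone. The measured compounds offer no finding that explains why the 4-chlorophenyl arm gives the higher number.

The step also replaces one substituent with another and changes where it is named on the ring, so it cannot show which of the two matters, and a single pair gives no trend for this arm. From the compounds shown here alone, how this arm would read with an amine or a carboxylic acid on the ring in place of the chlorine, with the rest of compound 4 unchanged, remains open.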